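Amine Substitution on a Fused Bicyclic Ether Series

The source may hold more compounds than are shown below. What is called first, only, known or untested is meant among the compounds shown, and "the series" means these compounds.

Working notes on the series, assessed in a functional assay on CHO-K1 cells for agonist activity at trace amine-associated receptor 1 (Homo sapiens), read by HTRF and cAMP accumulation, with a stated time of 30 min; a lower number here means that less compound is needed, a higher number that more compound is needed for the effect. Compound 2 `NC[C@@H]1OCCc2ccsc21` gives 3.5 nM in this assay. Compound 1 `CNC[C@]1(C)OCCc2ccsc21` differs from compound 2 in several places. In this assay compound 1 gives 45700 nM. For the measured compounds named here, compound 2 therefore holds the lower number of the two measured so far, and its distance from compound 1 lies well beyond the scatter of repeated measurement.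

Compound 3 `CN(C)C[C@@H]1OCCc2ccsc21` is the next compound to be measured in this assay. It differs from compound 2 by a single change: dimethylamino in place of amino on a saturated chain carbon bound to a saturated ring carbon. Going by the values given here, no step between two measured compounds covers this change on its own, and the only comparison available, compound 1 against compound 2, carries two differences at once and cannot serve as a guide to this one. The expectation for compound 3 is a step to a higher number, of a size beyond the scatter, a 57-fold higher number from compound 2 to compound 3 (1.76 log units; beyond the scatter). Compound 3 is accordingly estimated at 200 nM in this assay, with a range from 30 nM to 2000 nM.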

Compound 3, half-maximal effective concentration: 203 nM
Compound 3: middle estimate off by 1.0-fold (0.01 log units), on the low side; low and high end bracket the measured number.
By their numbers in this assay, from the lowest: compound 2; then compound 3; then compound 1.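

In this assay, for the compounds shown here, dimethylamino in place of amino on a saturated chain carbon bound to a saturated ring carbon gives a large step, a 58-fold higher number from compound 2 to compound 3 (1.76 log units; beyond the scatter), and this is the first reading of a change in one place. The earlier pair, compound 1 and compound 2, differs in several places and could not show that this change alone carries the number well beyond the scatter; the present step shows that it does, with the rest of the structure held constant. No measurement in hand accounts for the size of this step.

The compounds shown leave open how much of the distance between compound 1 and compound 2 belongs to the methylamino group of compound 1 and how much to the other differences, since that pair cannot be resolved into separate steps. They also leave open how the number in this assay responds to other groups in the same place, such as ethylamino or a pyrrolidine ring joined through its nitrogen.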